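Series notes: one change repeated across two cores

The source may report more compounds than this note shows. Statements on the series, on what has been measured and on what is new or still open speak of the compounds shown alone.

Compound 1 `O=C1O/C(=C\Cn2cc(Cc3ccccc3)nn2)C(OCc2ccccc2)=C1OCc1ccccc1` carries the benzyl group; in a functional assay on U-937 cells (Homo sapiens) for antiproliferative activity, read by MTT assay, with a stated time of 24 h (on this read-out lower numbers stand for stronger inhibition and higher numbers for weaker inhibition), compound 1 gives only a limit, > 100000 nM. Compound 2 `Cc1ccc(-c2cn(C/C=C3\OC(=O)C(OCc4ccccc4)=C3OCc3ccccc3)nn2)cc1` differs from it by 4-methylphenyl in place of benzyl on an aromatic carbon. In this assay compound 2 likewise gives a limit, > 100000 nM. The step that the two limits leave unreadable from compound 1 to compound 2 therefore cannot be read, which rests on (the limit of > 100000 nM in this assay, at which 3 of the 3 values shown sit). Compound 3 `O=C1NC(O)(CCn2cc(Cc3ccccc3)nn2)C(OCc2ccccc2)=C1OCc1ccccc1` has another core; the difference between the two cores is not broken down here. In this assay compound 3 gives a limit as well, > 100000 nM. Compound 4 `Cc1ccc(-c2cn(CCC3(O)NC(=O)C(OCc4ccccc4)=C3OCc3ccccc3)nn2)cc1`, not yet measured, differs from compound 3 by 4-methylphenyl in place of benzyl on an aromatic carbon, the same change at the same place as between compound 1 and compound 2. Going by the values given here, because the only precedent for this change is a step that the two limits leave unreadable from compound 1 to compound 2, the expected step that the limit leaves unreadable from compound 3 to compound 4 is estimated as equally unreadable. Compound 4 is expected to give 150000 nM, within 40000 nM to 600000 nM, most likely again only a limit.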

Compound 4, half-maximal inhibitory concentration: 54000 nM
For compound 4 the middle estimate is 2.8-fold (0.44 log units) above the measured one; low and high end bracket the measured number.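

In this assay, the change to 4-methylphenyl on the core of compound 3 gives an at least 1.8-fold lower number from compound 3 to compound 4 (0.26 log units; that floor lies within the scatter), and only compound 4 of the compounds shown has a measured number rather than a limit. As compound 3 gives only a limit, the step has a floor and no true size, and that floor does not establish a real gain. The steps with limits at both ends cannot be read, so whether the change carries from the core of compound 1 to the core of compound 3 is not shown: the limit of > 100000 nM in this assay, at which 3 of the 4 values shown sit.

Still open, on these data alone, is how an amine or a carboxylic acid in place of the methyl of the 4-methylphenyl group would read in this assay. As far as these compounds go, a longer chain in place of that methyl is equally open.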